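The source may report more compounds than this note shows. Statements on the series, on what has been measured and on what is new or still open speak of the compounds shown alone.

Working notes on the series, read in a functional assay on HepG2 cells (Homo sapiens) for inhibition, read by MTT assay, with a stated time of 72 h, tested at 50 uM; a higher number here means more inhibition of growth at the concentration tested, a lower number less inhibition of growth:

- compound 1 `C=CCc1ccc(OCc2cn(-c3cccc([N+](=O)[O-])c3)nn2)c(O)c1` gives 30.2%
- compound 2 `C=CCc1cc(O)c(O)c(CN2CCC(C)CC2)c1` gives 69.7%
- compound 3 `C=CCc1ccc(OCc2cn(-c3ccccc3Cl)nn2)c(O)c1` gives 4.7%

Compound 3 stands lowest of the three numbers in this assay. Its value lies beyond the scatter below both of the others, with compound 1 the nearer at 30.2% and compound 2 the further at 69.7%.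

The next compound is compound 4 `C=CCc1ccc(OCc2cn(-c3ccc(Br)cc3)nn2)c(O)c1`, not yet measured. It carries 4-bromophenyl in place of 2-chlorophenyl on an aromatic nitrogen. The rest of the structure of compound 3 is kept.

Within the data shown here, no step between measured compounds that differ in one place is available, so the expectation rests on thin ground. Among the measured compounds shown here, compound 1 is the only other measured compound that shares this general build, and it gives 30.2%, so a number above that of compound 3 seems more likely than one below it. A modest rise is expected, estimated as a number 13.3 percentage points higher from compound 3 to compound 4 (beyond the scatter), with a flat result not excluded.

For compound 4 the expected value is 18%, with an estimated range from 3% to 40%.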

Compound 4, percent growth inhibition at one concentration: 9.5%
Compound 4: the middle estimate sits 8.5 percentage points above what was measured; measured number inside the range.
By their numbers in this assay, from the lowest: compounds 3 and 4 (each within the scatter of the next); then compound 1; then compound 2.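

Read in this assay, the exchange of 2-chlorophenyl for 4-bromophenyl on an aromatic nitrogen of the five-membered ring gives a number 4.8 percentage points higher from compound 3 to compound 4 (within the scatter), the first step available at this position. Two features of the aryl group change together in this step, the halogen and where it sits, and the pair still cannot be told apart by this read-out, although the heavy-atom count of the group stays the same; the step therefore gives no separate reading for either feature, and the two contributions could be small or could offset each other. Nothing available bears on why compound 3 and compound 4 read alike.

A 4-chlorophenyl or 2-bromophenyl group would separate the halogen from its location, and an unsubstituted phenyl would show whether a halogen matters here at all. Also open, as far as these compounds go, is whether an aryl group carrying an amine or a carboxylic acid would read apart from this pair, and how the value of compound 1, at 30.2% with a nitro group on its phenyl ring, relates to that substituent.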